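The source may report more compounds than this note shows. Statements on the series, on what has been measured and on what is new or still open speak of the compounds shown alone.

Three compounds have been measured in a functional assay on HEK293 cells for antagonist activity at 5-hydroxytryptamine receptor 7 (Homo sapiens), read by luminescence and cAMP accumulation; a lower number here means a smaller maximal response, a higher number a larger maximal response:

Compound 1, `Fc1ccc(-c2noc3c2CCNCC3)cc1`, gave 98%.
Compound 2, `Fc1ccc(-c2n[nH]c3c2CCNCC3)cc1`, gave 98.4%.
Compound 3, `Clc1ccc(-c2noc3c2CCNCC3)cc1`, gave 94.9%.

Compound 3 differs from compound 1 by chloro in place of fluoro on an aromatic carbon, and this change gave a number 3.1 percentage points lower from compound 1 to compound 3 (within the scatter). Compound 2 and compound 1 share the same aryl group on different cores; the difference between the two cores is not broken down here. Compound 4, `Clc1ccc(-c2n[nH]c3c2CCNCC3)cc1`, has not yet been measured in this assay. It differs from compound 2 by chloro in place of fluoro on an aromatic carbon, which is the same change as that from compound 1 to compound 3, made at the same place. For compound 4 the expected step is a number 3.1 percentage points lower from compound 2 to compound 4 (within the scatter), resting on a number 3.1 percentage points lower from compound 1 to compound 3 (within the scatter). Compound 4 is thus estimated to give 95.3% in this assay, with a likely range from 87% to 100%. This expectation rests on a single measured pair, and the maximal response of compound 4 is expected to stay close to that of compound 2.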

Compound 4, largest response reached (reported as Imax), in percent of the reference or control that the assay uses: 94.8%
Beside the measured number, compound 4's estimate is 0.5 percentage points above it; low and high end bracket the measured number.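

In this assay, chloro in place of fluoro on the core of compound 2 gave a number 3.6 percentage points lower from compound 2 to compound 4 (within the scatter) and so matched the step on the core of compound 1: the same change on two cores in this assay, a number 3.1 percentage points lower (within the scatter) from compound 1 to compound 3 and a number 3.6 percentage points lower (within the scatter) from compound 2 to compound 4, 0.5 percentage points apart, within the scatter of two such steps. Within this series, the change therefore reads alike on these two cores, but each step lies within the scatter, so neither shows that the change alters the maximal response at all. Two cores and a single pair of halogens also cannot show that the step would hold on any further core, or for a change with a larger step.

The compounds shown leave open what a methoxy group, a nitrile or an amine would give in place of the halogen. They also leave open whether a methyl group on the core would keep the response where it stands.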